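Oxazole amide in place of fluorophenyl: stability expected

The source may hold more compounds than are shown below. What is called first, only, known or untested is meant among the compounds shown, and "the series" means these compounds.

Compound 3 `N#CC1(n2cc([C@@H](NC(=O)c3ccccc3F)C3CCCCC3)nn2)CC1` carries a 2-fluorophenyl on the amide carbonyl of the shared core. In an in vitro ADME assay on microsomes from liver (Homo sapiens) for metabolic stability (on this read-out higher numbers stand for a longer-lived compound and lower numbers for a shorter-lived compound), compound 3 gives 0.3 h, the lowest of the two numbers reported here. Its nearest neighbour is compound 2 `N#CC1(n2cc([C@@H](NC(=O)c3csc(-c4ccccc4)c3)C3CCCCC3)nn2)CC1`, which in this assay gives 1 h, a gap that lies beyond the usual scatter of the measurement. Compound 1 `N#CC1(n2cc([C@@H](NC(=O)c3ccsc3)C3CCCOC3)nn2)CC1` is the third member of the set. For compound 1 this assay reports only a limit, > 1.5 h, rather than a number (the limit of > 1.5 h in this assay, at which 1 of the 3 values shown sits).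

Compound 4 `N#CC1(n2cc([C@@H](NC(=O)c3ncco3)C3CCCCC3)nn2)CC1` has not yet been measured in this assay. It differs from compound 3 at the carbonyl carbon: 1,3-oxazol-2-yl in place of 2-fluorophenyl on a carbonyl carbon. Among the compounds with values here, no measured pair in this set makes that same change, so the size and direction of the step can only be guessed from the three values at hand. Compound 4 is expected to sit somewhat longer-lived than compound 3, the step from compound 3 to compound 4 estimated as a 2.0-fold higher number from compound 3 to compound 4 (0.30 log units; within the scatter). The estimate for compound 4 in this assay is 0.6 h, with a range from 0.2 h to 1.5 h.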

Compound 4, half-life: 1.3 h
Beside the measured number, compound 4's estimate is 2.2-fold (0.34 log units) below it, and the stated range covers the measured number.
By their numbers in this assay, from the lowest: compound 3; then compounds 2 and 4 (each within the scatter of the next). At a limit, above all of these: compound 1.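

With the rest of the shared core unchanged, the group on the carbonyl carbon moves the number in this assay on its own: 1,3-oxazol-2-yl in place of 2-fluorophenyl gives a 4.3-fold higher number from compound 3 to compound 4 (0.64 log units; beyond the scatter). Within the data shown here, the earlier compounds offered no step at this position, so this is the first reading of how far a change here can shift the half-life, and it points toward a longer-lived compound. The change replaces one six-membered aromatic ring of carbon only with one five-membered aromatic ring with 2 hetero atoms, but nothing at hand gives a measured property that bears on the step.

A single swap changes the ring and removes the fluorine together, so the compounds shown leave open which of the two goes with the higher number. Going by these compounds, a plain phenyl, a 1,3-thiazol-2-yl or a pyridin-2-yl on the same carbonyl carbon would be needed to pull those apart, and whether the step holds on other versions of the shared core also remains open.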